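The source may hold more compounds than are shown below. What is called first, only, known or untested is meant among the compounds shown, and "the series" means these compounds.

Measured so far:
- compound 1 `COc1cc(Nc2nc3ccccc3nc2S(=O)(=O)c2ccccc2)cc(OC)c1` gives 140 nM in a functional assay on PC-3 cells (Homo sapiens) for cytotoxicity, read by MTT assay, with a stated time of 72 h; on this read-out higher numbers stand for weaker inhibition and lower numbers for stronger inhibition
- compound 2 `O=S(=O)(c1ccccc1)c1nc2ccccc2nc1Nc1ccc(F)cc1` gives 14200 nM in this assay
- compound 3 `COc1cc(Nc2nc3ccccc3nc2S(=O)(=O)c2ccc(C)cc2)cc(OC)c1` gives 2940 nM in this assay

Compound 3 stands second highest of the three numbers in this assay: compound 1 sits well below it, by a 21-fold higher number from compound 1 to compound 3 (1.32 log units; beyond the scatter), while compound 2 sits above it, its value and that of compound 3 differing beyond the scatter.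

Compound 4 `Cc1ccc(S(=O)(=O)c2nc3ccccc3nc2Nc2ccc(F)cc2)cc1` is not yet measured. It differs from compound 3 in one place: 4-fluorophenyl in place of 3,5-dimethoxyphenyl on a nitrogen on an aromatic ring. The same replacement has been run once, on the core of compound 1, where it gave a 100-fold higher number from compound 1 to compound 2 (2.01 log units; beyond the scatter). The methyl that distinguishes compound 3 from compound 1 gave a 21-fold higher number from compound 1 to compound 3 (1.32 log units; beyond the scatter) on its own. Within the data shown here, whether the two changes add up fully is not known from the three measured compounds, but the one directly comparable step is large and points clearly toward a higher number in this assay, so a large step in the same direction is expected from compound 3 to compound 4, namely a 34-fold higher number from compound 3 to compound 4 (1.53 log units; beyond the scatter). Since the starting number of compound 3 is already high, the read-out for compound 4 may reach the top of the tested range and come back as a limit.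

Compound 4 is expected to give 100000 nM in this assay, within a range of 20000 nM to 400000 nM.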

Compound 4, half-maximal inhibitory concentration: 13100 nM
Beside the measured number, compound 4's estimate is 7.6-fold (0.88 log units) above it, outside the stated range (below it).
By their numbers in this assay, from the lowest: compound 1; then compound 3; then compounds 4 and 2 (each within the scatter of the next).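

The replacement of 3,5-dimethoxyphenyl by 4-fluorophenyl on the nitrogen still raises the number in this assay when the methyl is present, with a 4.5-fold higher number from compound 3 to compound 4 (0.65 log units; beyond the scatter), but the size of the step depends on the core: the same change on two cores in this assay, a 100-fold higher number (2.01 log units; beyond the scatter) from compound 1 to compound 2 and a 4.5-fold higher number (0.65 log units; beyond the scatter) from compound 3 to compound 4, 23-fold (1.36 log units) apart, beyond the scatter of two such steps

The methyl on the aromatic carbon likewise loses its effect once 4-fluorophenyl is in place, with a 1.1-fold lower number from compound 2 to compound 4 (0.04 log units; within the scatter), so its cost is seen only with 3,5-dimethoxyphenyl on the nitrogen: the same change on two cores in this assay, a 21-fold higher number (1.32 log units; beyond the scatter) from compound 1 to compound 3 and a 1.1-fold lower number (0.04 log units; within the scatter) from compound 2 to compound 4, 23-fold (1.36 log units) apart, beyond the scatter of two such steps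

The two changes therefore do not add up in this small set: each one alone raises the number from compound 1, while the second change adds less than it did alone, or nothing that can be read.

On these data alone, it remains open whether this coupling is specific to the methyl, or whether a chlorine, a methoxy or a carboxylic acid on the same aromatic carbon would behave alike. As far as these compounds go, it is also open whether both methoxy groups of the 3,5-dimethoxyphenyl are needed for the low number of compound 1, which a phenyl carrying a single methoxy group on the nitrogen would address.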